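Chloro to Bromo Exchange on a Fused Aromatic Ring

The compounds below may be only part of what the source reports. "The series", "measured", "known", "first", "only" and "open" are said of these compounds alone.

Three compounds have been measured in a functional assay on MCF7 cells (Homo sapiens) for antiproliferative activity, read by sulforhodamine B assay, with a stated time of 48 h; a higher number here means a weaker inhibitor of growth, a lower number a stronger inhibitor of growth:
compound 1, `O=C1C(=O)N(CCCNc2ccnc3cc(Cl)ccc23)c2cccc(Cl)c21`, 46700 nM
compound 2, `O=C1C(=O)N(CCCNc2ccnc3cc(Cl)ccc23)c2cccc(Br)c21`, 6570 nM
compound 3, `O=C1C(=O)N(CCCNc2ccnc3cc(C(F)(F)F)ccc23)c2cc(Cl)ccc21`, 14300 nM

Compound 1 and compound 2 share a core and differ in one place: bromo in place of chloro on an aromatic carbon. That change gives a 7.1-fold lower number from compound 1 to compound 2 (0.85 log units; beyond the scatter). Compound 3 carries a different core, and the difference between its core and the core of compound 1 is not broken down here. In this assay compound 3 stands between the other two, with a lower number than compound 1 and a higher number than compound 2.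

Compound 4, `O=C1C(=O)N(CCCNc2ccnc3cc(C(F)(F)F)ccc23)c2cc(Br)ccc21`, has not yet been measured. It differs from compound 3 in one place: bromo in place of chloro on an aromatic carbon. Within the data shown here, this is the same kind of change as the one from compound 1 to compound 2, but not the same change: in compound 1 and compound 2 the halogen sits ortho to a fused ring and meta to a fused ring, whereas in compound 3 and compound 4 it sits meta to a fused ring and para to a fused ring. Only one earlier instance of this kind of change exists among the compounds shown, and it was made on a different core, so a single step is a thin basis. The step in this assay is expected to run the same way, towards a lower number, yet it is set smaller than a 7.1-fold lower number from compound 1 to compound 2 (0.85 log units; beyond the scatter). The expected step is a 2.9-fold lower number from compound 3 to compound 4 (0.46 log units; beyond the scatter). For compound 4 in this assay the estimate is 5000 nM, with a likely range from 2000 nM to 13000 nM.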

Compound 4, concentration for 50% growth inhibition: 7980 nM
The estimate for compound 4 lay 1.6-fold (0.20 log units) below the measured number; low and high end bracket the measured number.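

In this assay, the exchange of chloro for bromo gives a 1.8-fold lower number from compound 3 to compound 4 (0.25 log units; within the scatter), so on this core the change is not shown to move the number beyond ordinary scatter. The step therefore does not carry over at its earlier size from the core of compound 1 to the core of compound 3, and the gap between the two instances is itself larger than scatter allows: the same change on two cores in this assay, a 7.1-fold lower number (0.85 log units; beyond the scatter) from compound 1 to compound 2 and a 1.8-fold lower number (0.25 log units; within the scatter) from compound 3 to compound 4, 4.0-fold (0.60 log units) apart, beyond the scatter of two such steps This shows that the effect of the exchange depends on the setting in which it is made, but it does not show what in that setting matters, since the two pairs differ both in a substituent elsewhere in the molecule and in where the halogen sits, and two steps are too few to make a rule.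

The compounds shown leave open whether the trifluoromethyl group or the place of the halogen accounts for the gap, as no pair separates the two. They also leave open how fluoro or iodo on this aromatic carbon, or a longer chain joining the two halves, would read in this assay.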